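A few compounds are considered here, and "the series" means these few. Any claim that something is new, unique, unknown or untested is made for them only; others in the source may bear on it.

The measured compounds so far:

- Compound 1 `NS(=O)(=O)c1ccccc1-c1cnc(C(=O)CCCCCCc2ccccc2)o1`, giving 1500 nM in an assay (Rattus norvegicus) for inhibition of Fatty-acid amide hydrolase 1 (Homo sapiens); on this read-out higher numbers stand for weaker inhibition and lower numbers for stronger inhibition
- Compound 2 `O=C(CCCCCCc1ccccc1)c1ncc(-c2ccc(O)cc2)o1`, giving 140 nM in this assay
- Compound 3 `COC(=O)c1ccc(-c2cnc(C(=O)CCCCCCc3ccccc3)o2)nc1`, giving 3.5 nM in this assay

All three share a core that carries a long chain ending in a phenyl ring, and they differ in the group attached to the five-membered aromatic ring. On these numbers compound 2 stands in the middle, second highest of the three: compound 1 gives a clearly higher number, beyond the usual scatter, and compound 3 a clearly lower number, also beyond the scatter. Within the data shown here, since no compound in this set has been measured in a pair that differs in one place only, the effect of changing just this group has not been isolated.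

Compound 4 `O=C(CCCCCCc1ccccc1)c1ncc(I)o1` has not yet been measured. It differs from compound 2 as follows: iodo in place of 4-hydroxyphenyl on an aromatic carbon

A whole aromatic ring with a hydroxyl is replaced by a single iodine atom. Among the measured compounds, the larger ring-bearing groups on compound 2 and compound 3 go with the lower numbers, while there is no measured compound with so small a group, so the expectation rests on extrapolation. The step from compound 2 to compound 4 is expected to be a rise, a 3.6-fold higher number from compound 2 to compound 4 (0.55 log units; beyond the scatter), most likely beyond the scatter. For compound 4 the expected value is 500 nM, within a range from 150 nM to 2000 nM.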

Compound 4, inhibition constant: 3 nM
Compound 4: the middle estimate sits 170-fold (2.22 log units) above what was measured; the measured number lies below the stated range.
By their numbers in this assay, from the lowest: compounds 4 and 3 (each within the scatter of the next); then compound 2; then compound 1.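

In this assay, replacing the 4-hydroxyphenyl with iodo on this aromatic carbon, next to the ring oxygen, gives a 47-fold lower number from compound 2 to compound 4 (1.67 log units; beyond the scatter). Among these compounds, all the earlier compounds carry a ring at this place, so they could not show that a low number needs neither a ring here nor a hydrogen-bond donor: iodo has 1 heavy atom against 7 for the group it replaces, no ring, and 0 hydrogen-bond donors. Nothing measured here explains the size of this step.

On these data alone, what remains open is whether the low number of compound 4 depends on iodine itself or would also appear with another small group at this place, such as a hydrogen atom, a methyl, a chloro or a bromo. A plain phenyl ring at the same place would also help, by showing whether the hydroxyl or the ring around it accounts for the higher number of compound 2.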